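The source may report more compounds than this note shows. Statements on the series, on what has been measured and on what is new or still open speak of the compounds shown alone.

Compound 1 `Nc1nc(N/N=C/c2ccc(-c3ccc(Br)cc3)o2)nc2c1ncn2[C@@H]1O[C@H](CO)[C@@H](O)[C@H]1O`, compound 2 `CCOc1cc(/C=N/Nc2nc(N)c3ncn([C@@H]4O[C@H](CO)[C@@H](O)[C@H]4O)c3n2)ccc1O` and compound 3 `Nc1nc(N/N=C/c2ccc(C(F)(F)F)cc2C(F)(F)F)nc2c1ncn2[C@@H]1O[C@H](CO)[C@@H](O)[C@H]1O` share one core and differ only in the aryl group carried on the carbon that bears a double bond to nitrogen. In an assay on CHO-K1 cells for displacement of a labelled ligand from adenosine receptor A1 (Homo sapiens), read by scintillation counting, with a stated time of 60 min (on this read-out lower numbers stand for stronger inhibition and higher numbers for weaker inhibition), compound 1 gives 4.5 nM, and compound 2 gives 6940 nM, the highest of the two numbers reported, far beyond the scatter from compound 1. For compound 3 this assay returns only a limit, > 10000 nM, and not a number; this is the case described by the limit of > 10000 nM in this assay, at which 1 of the 3 values shown sits.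

Compound 4 `Nc1nc(N/N=C/c2ccc(N3CCCC3)cc2)nc2c1ncn2[C@@H]1O[C@H](CO)[C@@H](O)[C@H]1O` has not yet been tested in this assay. It arises from compound 2 by one change: 4-(pyrrolidin-1-yl)phenyl in place of 3-ethoxy-4-hydroxyphenyl on a carbon with a double bond to nitrogen. Among the compounds with values here, the two measured neighbours of compound 2 point in opposite directions: compound 1 sits low, compound 3 at the limit, so the aryl group clearly sets the outcome, but the data give no directly comparable pair.

The step from compound 2 to compound 4 is expected to lower the number, by an amount beyond the scatter, a 23-fold lower number from compound 2 to compound 4 (1.36 log units; beyond the scatter). Compound 4 is therefore estimated at 300 nM in this assay, with a plausible range from 40 nM to 3000 nM, the wide span reflecting that compound 1 gives 4.5 nM while compound 2 gives 6940 nM with only the aryl group exchanged.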

Compound 4, inhibition constant: 5.1 nM
Beside the measured number, compound 4's estimate is 59-fold (1.77 log units) above it; measured number below the stated range.
By their numbers in this assay, from the lowest: compounds 1 and 4 (each within the scatter of the next); then compound 2. At a limit, above all of these: compound 3.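

In this assay, putting 4-(pyrrolidin-1-yl)phenyl in place of 3-ethoxy-4-hydroxyphenyl on a carbon with a double bond to nitrogen gives a 1400-fold lower number from compound 2 to compound 4 (3.13 log units; beyond the scatter), so this single exchange at this position is enough to carry a compound of this series from the high end of the measured numbers to the low end. Within the data shown here, compound 1 gives 4.5 nM and compound 4 gives 5.1 nM, within the scatter of each other, so a low number at this position is now reached with two different aryl groups and is not tied to the one in compound 1. The exchange removes the ethoxy and hydroxy substituents and brings in the pyrrolidine ring all at once, and nothing measured here tells which part of it accounts for the step.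

The compounds shown leave open whether the pyrrolidine ring itself matters, or whether a dimethylamino group or a morpholine ring on the same phenyl would give a similar number. They also leave open how a phenyl carrying only the hydroxy group or only the ethoxy group would stand.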